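Aryl ether variation in a diarylamine series

This account rests on a few compounds, and the source may have more. Where it says the series, first, only, none or still open, it means among the compounds named here.

Compound 1 `N#Cc1ccc(Oc2cccc(NCc3cccc(OC(F)(F)F)c3)c2)cc1` gives > 15000 nM in a functional assay on PLC5 cells (Homo sapiens) for inhibition, read by MTT assay, with a stated time of 24 h; on this read-out lower numbers stand for stronger inhibition and higher numbers for weaker inhibition; this is a limit of the assay, not a number.
Compound 2 `Nc1cc(Oc2cccc(NCc3cccc(OC(F)(F)F)c3)c2)ccc1[N+](=O)[O-]` gives 8300 nM in this assay.

For the measured compounds named here, compound 2 thus stands as the only compound with a measured number; the other value sits at the limit of > 15000 nM in this assay, at which 1 of the 2 values shown sits. Going by the values given here, the only measured step, an at least 1.8-fold lower number from compound 1 to compound 2 (0.25 log units; that floor lies within the scatter), has its floor within the scatter, so it shows only that the group on the ring oxygen can be changed without loss. Compound 3 `O=c1[nH]c2ccc(Oc3cccc(NCc4cccc(OC(F)(F)F)c4)c3)cc2[nH]1` differs from compound 2 by a group of 10 heavy atoms (7 carbon, 2 nitrogen, 1 oxygen; one five-membered aromatic ring with 2 hetero atoms, one six-membered aromatic ring of carbon only) in place of a group of 10 heavy atoms (6 carbon, 2 nitrogen, 2 oxygen; one six-membered aromatic ring of carbon only), on an oxygen on an aromatic ring. Among the compounds with values here, no measured step covers this pair of groups, so in this assay no change beyond the scatter is expected, with a lower number possible. Compound 3 is expected at 5000 nM, ranging from 1500 nM to 15000 nM. The expected step is a 1.7-fold lower number from compound 2 to compound 3 (0.22 log units; within the scatter).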

Compound 3, half-maximal inhibitory concentration: 10200 nM
The estimate for compound 3 lay 2.0-fold (0.31 log units) below the measured number; measured number inside the range.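

In this assay, two quite different groups on the ring oxygen now carry numbers that cannot be told apart, with a 1.2-fold higher number from compound 2 to compound 3 (0.09 log units; within the scatter). For the compounds shown here, the second exchange, which brings in a five-membered aromatic ring with 2 hetero atoms, also gives no separation from the nitrile compound, with an at least 1.4-fold lower number from compound 1 to compound 3 (0.16 log units; that floor lies within the scatter) as the only reading. Compound 1 remains a limit of the assay and not a number: the limit of > 15000 nM in this assay, at which 1 of the 3 values shown sits.

On these data alone, whether an amine or a carboxylic acid on this aryl group would move the number beyond the scatter stays open. So does the effect of replacing the trifluoromethoxy group, which is common to all the compounds shown.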